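Exchanging the valyl ester of compound 2 for a propanoyl ester

The compounds below may be only part of what the source reports. "The series", "measured", "known", "first", "only" and "open" are said of these compounds alone.

Three carbapenem-type ester prodrugs sharing one core have been followed in an ADME assay on the whole organism (plasma, strain Beagle) for pharmacokinetics, with Canis familiaris (Canis lupus familiaris) as the target, read by LC-MS, with a stated time of 8 h, at a dose of 10 mg/kg by the intraduodenal route; a lower number here means less compound in the circulation, a higher number more compound in the circulation at the dose given. Compound 1 `CC(C)C(=O)OCOC(=O)C1=C(S[C@@H]2CN[C@H](C(=O)Nc3cccc(C(=O)OCOC(=O)C(C)C)c3)C2)[C@H](C)[C@@H]2[C@@H]([C@@H](C)O)C(=O)N12` gives "below limit of detection" (no number reported), so no exposure could be seen for it. Compound 3 `C[C@@H](O)[C@H]1C(=O)N2C(C(=O)OCOC(=O)C(C)(C)C)=C(S[C@@H]3CN[C@H](C(=O)Nc4cccc(C(=O)OCOC(=O)C(C)(C)C)c4)C3)[C@H](C)[C@H]12` gives only a limit of the assay, < 70.4 ng.h/mL, and no number. Among the measured compounds shown here, compound 2 `CCOC(=O)C1=C(S[C@@H]2CN[C@H](C(=O)Nc3cccc(C(=O)OCC)c3)C2)[C@H](C)[C@@H]2[C@@H]([C@@H](C)OC(=O)[C@@H](N)C(C)C)C(=O)N12` is the one member of the set with a measured figure, giving 568 ng.h/mL in this assay. It therefore stands as the single fixed point of the set, the other two entries offering no number, as the limit of < 70.4 ng.h/mL in this assay, at which 1 of the 3 values shown sits, shows for one of them. Compound 4 `CCOC(=O)C1=C(S[C@@H]2CN[C@H](C(=O)Nc3cccc(C(=O)OCC)c3)C2)[C@H](C)[C@@H]2[C@@H]([C@@H](C)OC(=O)CC)C(=O)N12` has not yet been measured. It differs from compound 2 by ethyl in place of 1-amino-2-methylpropyl on a carbonyl carbon. For the measured compounds named here, no measured pair in this set covers such a change, so the size of the step cannot be read from the data. Compound 4 is expected to give 200 ng.h/mL in this assay, in a range from 40 ng.h/mL to 800 ng.h/mL. The expected step is a 2.8-fold lower number from compound 2 to compound 4 (0.45 log units; beyond the scatter), a drop beyond the usual scatter, with a real chance that only a limit is reported.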

Compound 4, area under the concentration-time curve: 764 ng.h/mL
Estimate against measurement, compound 4: 3.8-fold (0.58 log units) below; the measured number falls inside the stated range.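

In this assay, among the compounds shown here, the change from 1-amino-2-methylpropyl to ethyl on a carbonyl carbon gives a 1.3-fold higher number from compound 2 to compound 4 (0.13 log units; within the scatter), the first step in this set that can be read, and the two esters cannot be told apart. At this position, then, a measurable exposure does not depend on the amine or on the defined stereocentre of the valyl group, as the simple propanoyl ester, with no hydrogen-bond donor or acceptor in its ethyl, stands level with it on the shared core. Nothing measured for these compounds gives a cause for this result.

The compounds shown leave open whether any acyl group is needed on this oxygen at all, as a free hydroxyl alongside the two ethyl esters is not among them. For the compounds shown here, they also leave open how far the tolerance at this carbonyl carbon extends, for instance to a longer chain such as butanoyl or a branched one such as isobutyryl, and no single pair tells what the ethyl esters themselves contribute.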